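Pyridin-2-yl for 2-methoxyphenyl: a small expected cytotoxicity step

This account rests on a few compounds, and the source may have more. Where it says the series, first, only, none or still open, it means among the compounds named here.

In an ADME assay on HEK293 cells (Homo sapiens) for cytotoxicity, read by fluorescence and resazurin assay, with a stated time of 24 h (on this read-out higher numbers stand for lower toxicity in this test and lower numbers for higher toxicity in this test), compound 1 (`O=S1(=O)C=C(Sc2nnc(C3CCCCC3)o2)c2ccccc21`) gives 3000 nM and compound 2 (`COc1ccccc1-c1nnc(SC2=CS(=O)(=O)c3ccccc32)o1`) gives 3000 nM at the digits reported, so the two stand level. Compound 3 (`COC(=O)c1ccc(-c2nnc(SC3=CS(=O)(=O)c4ccccc43)o2)cc1`) gives 4000 nM and stays within the scatter of compound 2. Compound 4 (`O=S1(=O)C=C(Sc2nnc(-c3ccccn3)o2)c2ccccc21`) has not yet been measured. In it, pyridin-2-yl stands in place of 2-methoxyphenyl on an aromatic carbon (pyridin-2-yl in place of 2-methoxyphenyl on an aromatic carbon). Within the data shown here, the one measured step at this place is no change at the digits printed from compound 1 to compound 2 (within the scatter) for 2-methoxyphenyl in place of cyclohexyl on an aromatic carbon. Compound 3 carries yet another group there, and its value shows no gap beyond the scatter. Among the measured compounds shown here, no measured compound carries pyridin-2-yl, so the expectation rests on these three alone, and no step beyond the scatter is foreseen. The expected step is a 1.2-fold higher number from compound 2 to compound 4 (0.07 log units; within the scatter) and it stays within the scatter. For compound 4 the estimated value in this assay is 3500 nM with 1500 nM to 8000 nM as the expected range.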

Compound 4, half-maximal cytotoxic concentration: 5000 nM
For compound 4 the middle estimate is 1.4-fold (0.15 log units) below the measured one; measured number inside the range.
By their numbers in this assay, from the lowest: compounds 1, 2, 3 and 4 (each within the scatter of the next).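

In this assay, among these compounds, pyridin-2-yl, the only group here with a hetero atom in its six-membered aromatic ring, gives a 1.7-fold higher number from compound 2 to compound 4 (0.22 log units; within the scatter) and a 1.7-fold higher number from compound 1 to compound 4 (0.22 log units; within the scatter). Replacing the carbon-only ring of 2-methoxyphenyl, or the cyclohexyl of compound 1, with this ring therefore opens no gap beyond the scatter, so this place on the five-membered aromatic ring has accepted all three groups without a clear shift in this read-out. No measurement shown here explains the small step.

As far as these compounds go, whether an amine, a carboxylic acid or a longer alkyl chain at this place would move the number beyond the scatter remains open. The compounds shown also leave open how changes elsewhere on the shared core would act.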